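Swapping Fluoro for Chloro on the Shared Core

The compounds below may be only part of what the source reports. "The series", "measured", "known", "first", "only" and "open" are said of these compounds alone.

Compound 1 `O=C(Nc1ccc(Cl)cc1)C(=O)N1CCC(c2ccnc3ccc(F)cc23)CC1` and compound 2 `N#Cc1ccc(NC(=O)C(=O)N2CCC(c3ccnc4ccc(F)cc34)CC2)cc1` are built on the same core and differ only in one group on the outer aromatic ring. In an assay on HEK cells for inhibition of Tryptophan 2,3-dioxygenase (Homo sapiens) (on this read-out lower numbers stand for stronger inhibition and higher numbers for weaker inhibition), compound 1 gives 6900 nM, while compound 2 gives 5500 nM. The step of a 1.3-fold lower number from compound 1 to compound 2 (0.10 log units; within the scatter) came from the exchange of cyano in place of chloro on an aromatic carbon. Among the two numbers measured so far, compound 1 carries the higher one, with compound 2 sitting close to it.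

Compound 3 `O=C(Nc1ccc(Cl)cc1)C(=O)N1CCC(c2ccnc3ccc(Cl)cc23)CC1` differs from compound 1 by chloro in place of fluoro on an aromatic carbon. Going by the values given here, this change sits on the fused part of the core, a different position from the one altered in the only measured step, so no measured step speaks directly to it; that single step stayed within the scatter and gives no pointer toward a direction. For compound 3 the expected outcome in this assay is therefore no step beyond the scatter, a 1.2-fold lower number from compound 1 to compound 3 (0.06 log units; within the scatter). Compound 3 is estimated at 6000 nM, within a range from 2500 nM to 15000 nM.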

Compound 3, half-maximal inhibitory concentration: 2500 nM
Compound 3: the middle estimate sits 2.4-fold (0.38 log units) above what was measured, and the stated range covers the measured number.
By their numbers in this assay, from the lowest: compound 3; then compounds 2 and 1 (each within the scatter of the next).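

Chloro in place of fluoro on this aromatic carbon, which belongs to the fused part of the shared core, gives a 2.8-fold lower number from compound 1 to compound 3 (0.44 log units; beyond the scatter) in this assay and counts as a modest change. It is the first step among these compounds to lie beyond the scatter, so the number responds to a single-atom exchange at this position, whereas the one earlier exchange, on the outer aromatic ring, could not be told apart from the ordinary spread of repeated measurements. No measurement offered here addresses what lies behind this shift, so the result stands as an observation about these two compounds alone.

One pair cannot show whether the number would keep falling with bromo at this carbon, or how it would respond to a different kind of group there, such as methyl, methoxy or an amine. It also leaves open whether the gain from chloro on the fused part would carry over to a compound with a nitrile on the outer ring, since that exchange is seen here only with chloro on the outer ring.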